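Compound 3 to compound 4: losing the 4-fluorophenyl

The source may hold more compounds than are shown below. What is called first, only, known or untested is meant among the compounds shown, and "the series" means these compounds.

Values in a functional assay on HCT-116 cells (Homo sapiens) for antiproliferative activity, read by MTT assay, with a stated time of 72 h (on this read-out lower numbers stand for stronger inhibition and higher numbers for weaker inhibition), for the measured compounds
compound 1 `COc1ncc(-c2ccc3c(c2)NC(=O)CO3)cc1NS(=O)(=O)c1ccc(F)cc1` gives 24900 nM
compound 2 `CC(C)N1C(=O)COc2ccc(-c3cnc(Cl)c(NS(=O)(=O)c4ccc(F)cc4)c3)cc21` gives 18900 nM
compound 3 `O=C1COc2ccc(-c3cnc(Cl)c(NS(=O)(=O)c4ccc(F)cc4)c3)cc2N1c1ccc(F)cc1` gives 34200 nM

The three values lie within the scatter of one another, so compound 3 stands in a single band with compound 1 and compound 2. Next in line is compound 4 `O=C1COc2ccc(-c3cnc(Cl)c(NS(=O)(=O)c4ccc(F)cc4)c3)cc2N1` with this change from compound 3 hydrogen in place of 4-fluorophenyl on an amide-type nitrogen in a ring in which hydrogen comes in place of 4-fluorophenyl on an amide-type nitrogen in a ring.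

Within the data shown here, one measured step bears directly on this nitrogen. It is a 1.8-fold higher number from compound 2 to compound 3 (0.26 log units; within the scatter) with 4-fluorophenyl in place of isopropyl, and it stays within the scatter. Compound 1 also carries hydrogen on that nitrogen, though with methoxy in place of chloro elsewhere, and it gives 24900 nM without standing apart from the other two. Across these three compounds no group on this nitrogen has moved the number beyond the scatter, and none of the three goes against that. The change expected in this assay is a 1.4-fold lower number from compound 3 to compound 4 (0.15 log units; within the scatter) and so no step beyond the scatter is anticipated. The estimate for compound 4 is 24000 nM with an expected range from 10000 nM to 50000 nM on this evidence.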

Compound 4, half-maximal inhibitory concentration: > 40000 nM
Compound 4: a limit, no number (the forecaster's own chance of this, stated with the estimate: 8%); middle value at least 1.6-fold (0.22 log units) away from the limit.
By their numbers in this assay, from the lowest: compounds 2, 1 and 3 (each within the scatter of the next). At a limit, above all of these: compound 4.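

In this assay, compound 4 gives a limit and not a number: the limit of > 40000 nM in this assay, at which 1 of the 4 values shown sits.

Hydrogen in place of isopropyl on the amide-type nitrogen gives an at least 2.1-fold higher number from compound 2 to compound 4 (0.32 log units; beyond the scatter), the first step at this position to pass the scatter, so the earlier picture of a nitrogen where no group moved the number no longer holds for the pair of compound 2 and compound 4. Hydrogen in place of 4-fluorophenyl gives only an at least 1.1-fold higher number from compound 3 to compound 4 (0.06 log units; that floor lies within the scatter), and chloro in place of methoxy on an aromatic carbon, the first reading of that change with hydrogen on the nitrogen in both compounds, gives an at least 1.6-fold higher number from compound 1 to compound 4 (0.20 log units; that floor lies within the scatter); neither floor passes the scatter, so neither change is shown to move the number, although the limit leaves both steps free to be larger.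

From the compounds shown here alone, the true size of all three steps stays open as long as compound 4 has only a limit in this assay. Also open, going by these compounds, is how a methyl group, a longer chain ending in an amine, or a chain carrying a carboxylic acid on this nitrogen would read against hydrogen and isopropyl.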